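A few compounds are considered here, and "the series" means these few. Any claim that something is new, unique, unknown or untested is made for them only; others in the source may bear on it.

Measured in a functional assay on NCI-H460 cells (Homo sapiens) for cytotoxicity, read by sulforhodamine B assay, with a stated time of 24 h (on this read-out higher numbers stand for weaker inhibition and lower numbers for stronger inhibition), so far
- compound 1 `CC(C)C(=O)SCCCCC[C@H](NC(=O)[C@@H]1CCCC(=O)N1)C(=O)NC1CCCCC1` at 3700 nM
- compound 2 `CC(=O)SCCCCC[C@H](NC(=O)[C@H]1CCC(=O)N1)C(=O)Nc1cccc(C(F)(F)F)c1` at 30 nM

Compound 2 holds the lower of the two numbers, and its gap to compound 1 lies beyond the scatter. Within the data shown here, the series has no measured pair that differs in one place, so it offers no direct guide to the next change, and any expectation here rests on thin evidence.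

Going from compound 2 to compound 3 `CC(=O)SCCCCC[C@H](NC(=O)[C@H]1CCC(=O)N1)C(=O)Nc1cccc(C)c1` puts methyl in place of trifluoromethyl on an aromatic carbon and leaves the rest of the structure unchanged. In this assay a modest move towards a higher number is expected, with an estimated size of a 2.3-fold higher number from compound 2 to compound 3 (0.37 log units; beyond the scatter) and a wide margin around it. The value of compound 3 is estimated at 70 nM (expected range 20 nM to 300 nM).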

Compound 3, half-maximal inhibitory concentration: 40 nM
Beside the measured number, compound 3's estimate is 1.8-fold (0.24 log units) above it, within the range that was stated.
By their numbers in this assay, from the lowest: compounds 2 and 3 (each within the scatter of the next); then compound 1.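

In this assay, among these compounds, putting methyl in place of trifluoromethyl on this aromatic carbon gives a 1.3-fold higher number from compound 2 to compound 3 (0.12 log units; within the scatter), the first step that changes a single place. The change removes three fluorine atoms and leaves a single carbon in the group, yet the two compounds remain within the scatter of each other, so on this core in this assay the trifluoromethyl group is interchangeable with methyl. No measurement at hand bears on why the two groups read alike.

From the compounds shown here alone, whether this aromatic carbon accepts other kinds of group, such as an amine, a carboxylic acid or a longer alkyl chain, remains open, as does the result of a bare hydrogen there. Going by these compounds, it is also open whether the methyl and trifluoromethyl groups would still read alike with a cyclohexyl amide or a different thioester on the core.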